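Swapping Chlorine for Fluorine on a Benzyl Triazole

The compounds below may be only part of what the source reports. "The series", "measured", "known", "first", "only" and "open" are said of these compounds alone.

Compound 1, `O=C1/C(=C/c2ccccc2F)CN(C(=S)SCc2cn(Cc3ccccc3Cl)nn2)C/C1=C\c1ccccc1F`: > 80000 nM
Compound 2, `O=C1/C(=C/c2ccccc2F)CN(C(=S)SCc2cn(Cc3ccccc3F)nn2)C/C1=C\c1ccccc1F`: > 80000 nM
Compound 3, `COc1ccc(/C=C2\CN(Cc3cn(Cc4ccccc4Cl)nn3)C/C(=C\c3ccc(OC)cc3)C2=O)cc1`: 36300 nM

All three were tested in a functional assay on PC-3 cells (Homo sapiens) for cytotoxicity, read by MTT assay, with a stated time of 24 h; a lower number here means a stronger inhibitor, a higher number a weaker inhibitor. For compound 1 the reading is a limit of the assay, not a number, as the limit of > 80000 nM in this assay, at which 2 of the 3 values shown sit, shows. For compound 2 the reading is the same kind of limit. Because both sit at the limit of > 80000 nM in this assay, at which 2 of the 3 values shown sit, the step that the two limits leave unreadable from compound 1 to compound 2 cannot be read, although the change itself is plain: fluoro in place of chloro on an aromatic carbon. Compound 3 is the only one of the three with a real number; in this assay compound 3 gives 36300 nM. Compound 3 and compound 1 carry the same benzyl triazole arm, but the difference between their two cores is not broken down here.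

Compound 4, `COc1ccc(/C=C2\CN(Cc3cn(Cc4ccccc4F)nn3)C/C(=C\c3ccc(OC)cc3)C2=O)cc1`, has not yet been measured. It stands to compound 3 as compound 2 stands to compound 1: fluoro in place of chloro on an aromatic carbon. The surroundings of the changed atom read the same in both pairs, so this is the same change. The measured pair gives no size for it, since both of its readings are limits.

The change is a single halogen swap, and compound 3 already sits far toward the weak end, so the step of a 1.1-fold higher number from compound 3 to compound 4 (0.04 log units; within the scatter) is expected to be small. Compound 4 is expected to give about 40000 nM in this assay, most likely between 15000 nM and 80000 nM, with a fair chance that only a limit is reported.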

Compound 4, half-maximal inhibitory concentration: 39900 nM
For compound 4 the middle estimate is 1.0-fold (0.00 log units) above the measured one, and the stated range covers the measured number.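

In this assay, replacing 2-chlorobenzyl with 2-fluorobenzyl on the core of compound 3 gives a 1.1-fold higher number from compound 3 to compound 4 (0.04 log units; within the scatter), so on this core the two halogens cannot be told apart, and this is the only readable measure of the change in the compounds shown. The same swap also links compound 1 and compound 2, but that step cannot be read, because neither compound gives a real number, only a limit of the assay: the limit of > 80000 nM in this assay, at which 2 of the 4 values shown sit. The result therefore shows that the swap makes no measurable difference on one core, but it does not show that the change carries over from one core to the other, since the second core offers no size to set beside it.

At this place on the benzyl ring, the compounds shown carry only chloro and fluoro, which leaves open whether a different group there, such as a nitrile or an amine, would move the reading in this assay beyond the scatter. On these data alone, it also remains open whether the swap would leave the reading just as unchanged on a third core, where both partners gave real numbers.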